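This account rests on a few compounds, and the source may have more. Where it says the series, first, only, none or still open, it means among the compounds named here.

Measured so far:
- compound 1, `COc1ccc(/C(C)=C/CN(C)C)cc1`: 806 nM
- compound 2, `C/C(=C\CN1CCCCC1)c1ccc(-c2ccccc2)cc1`: 0.86 nM

Both compounds were tested in an assay on cell membranes for displacement of a labelled ligand from Sigma non-opioid intracellular receptor 1 (Cavia porcellus), read by scintillation counting, with a stated time of 150 min; on this read-out higher numbers stand for weaker inhibition and lower numbers for stronger inhibition. Compound 1 gives 806 nM in this assay, and compound 2 gives 0.86 nM. Of the two numbers, compound 2 has the lower one, and the gap to compound 1 is far beyond the usual scatter, so compound 2 is clearly the stronger binder of the pair. Compound 1 and compound 2 differ in more than one place, so no single structural change can be read from that gap.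

Compound 3, `C/C(=C\CN(C)C)c1ccc(-c2ccccc2)cc1`, has not yet been measured. It keeps the core of compound 2 and carries one change: dimethylamino in place of piperidin-1-yl on a saturated chain carbon bound to a double-bonded chain carbon. For the measured compounds named here, no measured pair in this set isolates that exchange, so its effect here is not known. The expected step for compound 3 is a 5.8-fold higher number from compound 2 to compound 3 (0.76 log units; beyond the scatter) toward a higher number, so that compound 3 is expected to stay a strong binder while losing some ground. Compound 3 is estimated at 5 nM in this assay, with a range from 1.5 nM to 20 nM.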

Compound 3, inhibition constant: 1.4 nM
Compound 3: middle estimate off by 3.6-fold (0.55 log units), on the high side, and the stated range ends above it.
By their numbers in this assay, from the lowest: compounds 2 and 3 (each within the scatter of the next); then compound 1.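

In this assay, putting dimethylamino in place of piperidin-1-yl on a saturated chain carbon bound to a double-bonded chain carbon gives a 1.6-fold higher number from compound 2 to compound 3 (0.21 log units; within the scatter) and so shows that, on this core, the ring of piperidin-1-yl and its extra heavy atoms are not needed for a low number. Compound 3 also offers a one-place comparison that the first two compounds could not give: with dimethylamino kept on the chain, phenyl in place of methoxy on an aromatic carbon gives a 580-fold lower number from compound 1 to compound 3 (2.76 log units; beyond the scatter) and is a large change in this series. Nothing shown here gives a reason for either step.

The compounds shown leave open whether other amines at this chain position, such as morpholin-4-yl or a primary amine, would give similar numbers, as only two amine groups appear here. They also leave open how other groups on the aromatic carbon, such as a chlorine atom or a longer alkoxy chain, would compare with phenyl and methoxy, and whether piperidin-1-yl would give a similar number with methoxy on that carbon.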